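Swapping a Ring on the Triazole in a Lactam Series

This account rests on a few compounds, and the source may have more. Where it says the series, first, only, none or still open, it means among the compounds named here.

Three compounds with a measurement share a triazole-bearing side chain attached to a small ring core. Compound 1 `O=C1O/C(=C\Cn2cc(C3=CCCCC3)nn2)C(OCc2ccccc2)=C1OCc1ccccc1` carries an exocyclic double bond on its core. In a functional assay on MDA-MB-231 cells (Homo sapiens) for antiproliferative activity, read by MTT assay, with a stated time of 24 h (on this read-out higher numbers stand for weaker inhibition and lower numbers for stronger inhibition), compound 1 gives > 100000 nM, which is the assay limit, (the limit of > 100000 nM in this assay, at which 1 of the 3 values shown sits), and so offers no number to compare. Compound 2 `O=C1NC(O)(CCn2cc(C3=CCCCC3)nn2)C(OCc2ccccc2)=C1OCc1ccccc1` is the closely related lactam with a hydroxyl on the core and a saturated linker to the triazole, and in this assay compound 2 gives 13100 nM. Compound 3 `COC1=C(OC)C(O)(CCn2cc(-c3ccc(C(C)(C)C)cc3)nn2)NC1=O` keeps the same lactam core with methoxy groups in place of the benzyloxy groups and a tert-butylphenyl on the triazole; in this assay compound 3 gives 11300 nM. The values of compound 2 and compound 3 lie within the usual scatter of each other, so neither can be called stronger.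

Compound 4 `O=C1NC(O)(CCn2cc(-c3ccccc3)nn2)C(OCc2ccccc2)=C1OCc1ccccc1` is compound 2 with one change: phenyl in place of cyclohex-1-en-1-yl on an aromatic carbon

Among the measured compounds shown here, no measured pair differs in only one place, so the size of this step is untested. Since compound 3, with an aromatic ring on the triazole, gives 11300 nM, the step from compound 2 to compound 4 is expected to stay within the scatter, a 1.1-fold lower number from compound 2 to compound 4 (0.04 log units; within the scatter). Compound 4 is therefore estimated at 12000 nM, with a range from 4000 nM to 40000 nM.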

Compound 4, half-maximal inhibitory concentration: 21100 nM
Compound 4: middle estimate off by 1.8-fold (0.25 log units), on the low side; low and high end bracket the measured number.
By their numbers in this assay, from the lowest: compounds 3, 2 and 4 (each within the scatter of the next). At a limit, above all of these: compound 1.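

In this assay, placing phenyl in place of cyclohex-1-en-1-yl on the aromatic carbon of the triazole gives a 1.6-fold higher number from compound 2 to compound 4 (0.21 log units; within the scatter). Among the compounds shown here, this is the first measured pair that differs in only one place, and it shows that this position accepts either a non-aromatic or an aromatic six-membered carbon ring with no change beyond the usual scatter, so the aromatic character of this ring makes no readable difference to antiproliferative activity in these cells. Nothing shown here bears on why the two rings read alike.

On these data alone, both groups have the same six carbons, so it remains open whether a ring carrying an amine or a carboxylic acid, a longer alkyl chain, or a single methyl at this position would move the number beyond the scatter. Compound 3 differs from compound 4 in more than one place, so the contribution of its tert-butyl group on the phenyl ring cannot be separated from that of the methoxy groups on its core.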